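The compounds below may be only part of what the source reports. "The series", "measured", "known", "first", "only" and "open" are said of these compounds alone.

Of the compounds shown here, three sharing one core have been measured in an assay on isolated protein for inhibition of Fatty-acid amide hydrolase 1 (Rattus norvegicus), with a stated time of 60 min; on this read-out lower numbers stand for stronger inhibition and higher numbers for weaker inhibition. Compound 1 `Cc1nc2cc(NC(=O)N3CCN(Cc4cccc(Oc5ccc(Cl)cc5)c4)CC3)ccc2o1` gives 200 nM, compound 2 `O=C(Nc1noc2cnccc12)N1CCN(Cc2cccc(Oc3ccc(Cl)cc3)c2)CC1` gives 0.7 nM, and compound 3 `O=C(Nc1noc2ccncc12)N1CCN(Cc2cccc(Oc3ccc(Cl)cc3)c2)CC1` gives 2200 nM, the highest of the three numbers and so the weakest inhibitor among them. Compound 4 `O=C(Nc1ccn2ccnc2c1)N1CCN(Cc2cccc(Oc3ccc(Cl)cc3)c2)CC1` differs from compound 3 by a group of 9 heavy atoms (7 carbon, 2 nitrogen; one five-membered aromatic ring with 2 hetero atoms, one six-membered aromatic ring with 1 hetero atom) in place of a group of 9 heavy atoms (6 carbon, 2 nitrogen, 1 oxygen; one five-membered aromatic ring with 2 hetero atoms, one six-membered aromatic ring with 1 hetero atom), on an amide-type nitrogen. Every measured step exchanges a group at this same place: a 290-fold lower number from compound 1 to compound 2 (2.46 log units; beyond the scatter), an 11-fold higher number from compound 1 to compound 3 (1.04 log units; beyond the scatter) and a 3100-fold higher number from compound 2 to compound 3 (3.50 log units; beyond the scatter). Such exchanges have moved this assay by large amounts in both directions, so a large step is expected for compound 4, though its direction is uncertain. Compound 3 already sits at the weak end with 2200 nM, so a downward move is estimated: a 15-fold lower number from compound 3 to compound 4 (1.17 log units; beyond the scatter). For compound 4 the estimate is 150 nM, ranging from 10 nM to 2000 nM.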

Compound 4, half-maximal inhibitory concentration: 2600 nM
Estimate against measurement, compound 4: 17-fold (1.24 log units) below; the whole stated range lies below it.
By their numbers in this assay, from the lowest: compound 2; then compound 1; then compounds 3 and 4 (each within the scatter of the next).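

In this assay, the step is a 1.2-fold higher number from compound 3 to compound 4 (0.07 log units; within the scatter), so exchanging one group of 9 heavy atoms for another at this place need not move the number, unlike the earlier exchanges. With a 3700-fold higher number from compound 2 to compound 4 (3.57 log units; beyond the scatter) and a 13-fold higher number from compound 1 to compound 4 (1.11 log units; beyond the scatter), compound 4 joins compound 3 at the weak end, leaving compound 2 as the strongest inhibitor by far. Nothing available explains these differences. Still open, from the compounds shown here alone, is how a plain phenyl group, with its single ring, would read on this amide-type nitrogen. Also open, going by these compounds, is whether adding an amine to the group of compound 2 would keep its low number.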